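Thiocarbonyl series: ethylamino replaces acetamidoethylsulfanyl

The source may hold more compounds than are shown below. What is called first, only, known or untested is meant among the compounds shown, and "the series" means these compounds.

Compound 1 `CCNC(=O)SCC(=O)c1ccc(OC)cc1`: 132 nM
Compound 2 `COc1ccc(C(=O)CSC(=S)SCCNC(C)=O)cc1`: 1640 nM

In an assay on HEK293 cells for inhibition of protein deacetylase HDAC6 (Homo sapiens) (a lower number here means a stronger inhibitor, a higher number a weaker inhibitor), compound 2 gives the highest of the two numbers; its nearest neighbour is compound 1, whose number is lower by a margin beyond the usual scatter. Compound 3 `CCNC(=S)SCC(=O)c1ccc(OC)cc1` differs from compound 2 by ethylamino in place of (2-acetamidoethyl)sulfanyl on a thiocarbonyl carbon. Within the data shown here, no step between measured compounds covers this change. Because compound 1 carries the same ethylamino group and gives 132 nM, a lower number than compound 2 is expected for compound 3. The expected step is a 6.6-fold lower number from compound 2 to compound 3 (0.82 log units; beyond the scatter). Compound 3 is therefore estimated at 250 nM, within a range of 60 nM to 1000 nM.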

Compound 3, half-maximal inhibitory concentration: 94 nM
Compound 3: middle estimate off by 2.7-fold (0.42 log units), on the high side; measured number inside the range.
By their numbers in this assay, from the lowest: compounds 3 and 1 (each within the scatter of the next); then compound 2.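

In this assay, ethylamino in place of (2-acetamidoethyl)sulfanyl on a thiocarbonyl carbon gives a 17-fold lower number from compound 2 to compound 3 (1.24 log units; beyond the scatter), showing that the group at this position strongly affects the number. With ethylamino kept, thiocarbonyl in place of carbonyl gives a 1.4-fold lower number from compound 1 to compound 3 (0.15 log units; within the scatter), so compound 1 and compound 3 cannot be separated here. In this pair, the exchange of oxygen for sulfur therefore has no effect that can be read beyond the scatter.

As far as these compounds go, how methylamino, propylamino or morpholine would behave on the same thiocarbonyl carbon remains open. Nothing shown gives a reason for either step.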